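Series notes: isopropyl to butyl on the shared core

The source may report more compounds than this note shows. Statements on the series, on what has been measured and on what is new or still open speak of the compounds shown alone.

Measured compounds:
Compound 1 `CCCc1nc(C)c2c(C(C)C)nnc(O)n12` — in a functional assay for inhibition, with Homo sapiens as the target (a higher number here means a weaker inhibitor, a lower number a stronger inhibitor), compound 1 gives > 48000 nM, a limit of the assay.
Compound 2 `CCCc1nc(C)c2c(C(C)C)nnc(S)n12` — in this assay compound 2 gives > 48000 nM, also a limit.

For the measured compounds named here, compound 1 therefore stands only at a limit, and the one further value is a limit as well; both sit at the limit of > 48000 nM in this assay, at which 2 of the 2 values shown sit. The sulfanyl for hydroxy change gives a step that the two limits leave unreadable from compound 1 to compound 2. Compound 3 `CCCCc1nnc(O)n2c(CCC)nc(C)c12` differs from compound 1 by butyl in place of isopropyl on an aromatic carbon. Going by the values given here, no measured step bears on an alkyl change, and the only measured step is unreadable. The expected step is a step that the limit leaves unreadable from compound 1 to compound 3, that is, no movement away from the limit. Compound 3 is estimated at 70000 nM, between 20000 nM and 250000 nM.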

Compound 3, half-maximal inhibitory concentration: > 48000 nM
Compound 3: no number, only a limit; the forecaster's own chance of this, stated with the estimate: 85%; the middle value lies beyond the limit too.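

Compound 1 and compound 3 both stand only at a limit, so no step can be read between them: the limit of > 48000 nM in this assay, at which 3 of the 3 values shown sit.

The compounds shown leave open whether any change on the shared core gives a readable value in this assay.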